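Removing the phenyl from a triazine core: compound 4

This account rests on a few compounds, and the source may have more. Where it says the series, first, only, none or still open, it means among the compounds named here.

Compound 1, `CCCc1nc(C)c2c(-c3ccccc3)nnc(SC)n12` — in a functional assay for inhibition, with Homo sapiens as the target (a higher number here means a weaker inhibitor, a lower number a stronger inhibitor), compound 1 gives > 48000 nM, which is a limit of the assay and not a number.
Compound 2, `CSc1nnc(-c2ccccc2)c2c(C)nc(C(C)C)n12` — in this assay compound 2 gives > 48000 nM, again a limit.
Compound 3, `CCCc1nc(C)c2c(-c3ccccc3)nnc(O)n12` — in this assay compound 3 gives > 48000 nM, also a limit.

Compound 1 therefore stands nowhere definite on the numbers shown: all three measured compounds sit at the same limit, as the limit of > 48000 nM in this assay, at which 3 of the 3 values shown sit, states, so neither a step that the two limits leave unreadable from compound 1 to compound 2 nor a step that the two limits leave unreadable from compound 1 to compound 3 can be read for size or direction.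

Compound 4, `CCCc1nc(C)c2cnnc(SC)n12`, differs from compound 1 in one place: hydrogen in place of phenyl on an aromatic carbon. Within the data shown here, none of the measured steps touches the phenyl, so there is no step of known size to lean on. Among the measured compounds shown here, the only guide is that compound 1, compound 2 and compound 3 all remain at the limit whatever is changed at the propyl or methylsulfanyl position.

On that basis compound 4 is expected to behave like its neighbours, with a step that the limit leaves unreadable from compound 1 to compound 4 that is more likely to stay at the limit than to reach a number. The estimate for compound 4 in this assay is 100000 nM, within 20000 nM to 500000 nM.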

Compound 4, half-maximal inhibitory concentration: > 48000 nM
Compound 4 ended at the assay's limit; the forecaster's own chance of this, stated with the estimate: 85%; the middle value is on the limit's open side.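

In this assay compound 4 gives > 48000 nM, which is a limit of the assay and not a number. Compound 1 sits at that same limit, so no size or direction can be read for the step between compound 1 and compound 4: the limit of > 48000 nM in this assay, at which 4 of the 4 values shown sit.

The compounds shown leave open whether any change to the shared core would give a real number in this assay.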